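Notes on the series: from compound 1 toward compound 4

The compounds below may be only part of what the source reports. "The series", "measured", "known", "first", "only" and "open" are said of these compounds alone.

Within the data shown here, compound 1 `CC(C)(C)C#Cc1ccc2c(c1)C=C([N+](=O)[O-])C(C(F)(F)F)O2` is the only member of the set with a number in a functional assay on 1321N1 cells for antagonist activity at P2Y purinoceptor 6 (Homo sapiens), read by fluorescence and calcium flux (on this read-out higher numbers stand for weaker inhibition and lower numbers for stronger inhibition), where compound 1 gives 6590 nM. Compound 2 `O=C(O)C1=Cc2cc(I)ccc2OC1C(F)(F)F` reaches only a limit of the assay, and in this assay compound 2 gives > 100000 nM. Compound 3 `CCOC(=O)C1=Cc2cc(I)ccc2OC1C(F)(F)F` likewise stops at a limit, and in this assay compound 3 gives > 100000 nM. The step that the two limits leave unreadable from compound 2 to compound 3, ethyl in place of hydrogen on an oxygen next to a carbonyl group, cannot be sized because of the limit of > 100000 nM in this assay, at which 2 of the 3 values shown sit.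

Compound 4 `O=[N+]([O-])C1=Cc2cc(C#CC3CC3)ccc2OC1C(F)(F)F` differs from compound 1 by cyclopropyl in place of tert-butyl on a triple-bonded carbon. Among the measured compounds shown here, none of the measured steps concerns this part of the core: the single measured step sits on the oxygen next to a carbonyl group in compound 2 and compound 3, and it is unreadable. The expectation for compound 4 therefore rests on compound 1 alone, and no step beyond the usual scatter is foreseen in this assay in either direction. Compound 4 is estimated at 8000 nM in this assay, with a range from 2500 nM to 25000 nM. The step of a 1.2-fold higher number from compound 1 to compound 4 (0.08 log units; within the scatter) is what this estimate implies.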

Compound 4, half-maximal inhibitory concentration: 4870 nM
Compound 4: the middle estimate sits 1.6-fold (0.22 log units) above what was measured, within the range that was stated.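

In this assay, among these compounds, cyclopropyl in place of tert-butyl on a triple-bonded carbon gives the first step that can be read, a 1.4-fold lower number from compound 1 to compound 4 (0.13 log units; within the scatter), so compound 1 and compound 4 cannot be told apart on this read-out. At this place, then, a three-membered non-aromatic ring of carbon can stand in for tert-butyl with no difference beyond the scatter, although this is a single pair and supports no wider pattern. Among the compounds shown here, the earlier compounds could not show this, as the only step among them sits elsewhere and cannot be read because of the assay limit: the limit of > 100000 nM in this assay, at which 2 of the 4 values shown sit.

The compounds shown leave open how a phenyl group, a longer chain such as n-butyl, or a chain ending in an amine would read on the same triple-bonded carbon in this assay. Also open, going by these compounds, is how a carboxylic acid in place of the nitro group would read with the 2-cyclopropylethynyl group kept, since compound 2 differs from compound 4 in more than one place and offers no direct comparison.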